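Epimer of a cyclohexane acid sugar mimic: expected binding

A few compounds are considered here, and "the series" means these few. Any claim that something is new, unique, unknown or untested is made for them only; others in the source may bear on it.

Measured so far:
- Compound 1, `COc1ccc(CCCC(=O)O)cc1C1OC(C)C(O)C(O)C1O`: 5000 nM
- Compound 2, `COc1ccc(C2(C(=O)O)CCCCC2)cc1[C@H]1O[C@@H](C)[C@@H](O)[C@H](O)[C@@H]1O`: 7000 nM

Both values come from an assay on isolated protein for binding affinity to P-selectin (Homo sapiens), read by ELISA; on this read-out lower numbers stand for stronger inhibition and higher numbers for weaker inhibition. Compound 1 gives 5000 nM and compound 2 gives 7000 nM in this assay, and the two numbers lie within the usual scatter of each other, so neither compound can be said to bind more strongly than the other.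

Compound 3, `COc1ccc(C2(C(=O)O)CCCCC2)cc1[C@H]1O[C@@H](C)[C@H](O)[C@H](O)[C@@H]1O`, has not yet been measured. Its relation to compound 2 is the two compounds have the same atoms and bonds and differ only in configuration as drawn: 1 of 5 stereo elements differ; a stereocentre at a saturated ring carbon is drawn S in compound 2 and R in compound 3. For the measured compounds named here, no step between two measured compounds shows what such a change in configuration does in this assay, so the expectation rests on the change itself rather than on a precedent. A single change of configuration on the sugar ring is expected to weaken binding modestly, by the step of a 2.1-fold higher number from compound 2 to compound 3 (0.33 log units; beyond the scatter). Compound 3 is therefore expected to give about 15000 nM in this assay, within a range from 4000 nM to 60000 nM.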

Compound 3, half-maximal inhibitory concentration: 22000 nM
Estimate against measurement, compound 3: 1.5-fold (0.17 log units) below, within the range that was stated.
By their numbers in this assay, from the lowest: compounds 1 and 2 (each within the scatter of the next); then compound 3.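

Drawing this saturated ring carbon as R rather than S gives a 3.1-fold higher number from compound 2 to compound 3 (0.50 log units; beyond the scatter) in this assay, a modest weakening but one beyond the scatter. For the compounds shown here, this is the first measured step to show that the assay can tell apart two compounds with the same atoms and bonds, so the configuration at this one carbon counts for binding. The weakening can be assigned to that carbon alone because nothing else changes: the fact that compounds 2 and 3 differ only in the configuration as drawn

The compounds shown leave open whether changing the configuration at the other stereocentres would weaken binding by a similar amount, or at all. They also leave open how an amine in place of the carboxylic acid would read, and whether the R and S forms would then still differ.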